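Difluoromethyl to 1-Fluoroethyl on a Urea Kinase Inhibitor

A few compounds are considered here, and "the series" means these few. Any claim that something is new, unique, unknown or untested is made for them only; others in the source may bear on it.

Compound 1 `CNc1cc(Oc2ccc(NC(=O)Nc3cccc(C(F)F)c3)cc2)ncn1` gives 100 nM in an assay on isolated protein for inhibition of serine/threonine-protein kinase TNNI3K (Homo sapiens); a lower number here means a stronger inhibitor, a higher number a weaker inhibitor. Compound 2 `COc1cc(Oc2ccc(NC(=O)Nc3cccc(C(F)(F)F)c3)cc2)ncn1` gives 4000 nM. Compound 3 `CNc1cc(Oc2c(C)cc(NC(=O)Nc3cccc(C(F)(F)F)c3)cc2C)ncn1` gives 25 nM.

Among these three, compound 1 stands second highest; compound 3 lies lower, beyond the scatter, and compound 2 lies far higher, also beyond the scatter. Compound 4 `CNc1cc(Oc2ccc(NC(=O)Nc3cccc(C(C)F)c3)cc2)ncn1` differs from compound 1 by methyl in place of fluoro on a saturated chain carbon bound to an aromatic carbon and a fluorine atom, the difluoromethyl becoming a 1-fluoroethyl. Among the measured compounds shown here, no measured pair shows this exchange, so nothing here tells its direction. The author expects a small step, likely toward a weaker inhibitor but close to the scatter, in a 1.6-fold higher number from compound 1 to compound 4 (0.20 log units; within the scatter). Compound 4 is estimated at 160 nM, within 50 nM to 500 nM.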

Compound 4, half-maximal inhibitory concentration: 79 nM
Beside the measured number, compound 4's estimate is 2.0-fold (0.31 log units) above it; low and high end bracket the measured number.
By their numbers in this assay, from the lowest: compound 3; then compounds 4 and 1 (each within the scatter of the next); then compound 2.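

In this assay, the exchange gives a 1.3-fold lower number from compound 1 to compound 4 (0.10 log units; within the scatter), a step within the scatter, so difluoromethyl and 1-fluoroethyl cannot be told apart at this place on the core of compound 1. This first one-place step shows that, on a saturated chain carbon bound to an aromatic carbon and a fluorine atom, methyl can stand in place of fluoro without a step beyond the scatter. Nothing at hand offers a measured explanation for this result.

The compounds shown leave open whether a longer chain, such as propyl, or an amine on that carbon would also stay within the scatter of compound 1. They also leave open whether a hydroxyl there would do so.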